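The source may report more compounds than this note shows. Statements on the series, on what has been measured and on what is new or still open speak of the compounds shown alone.

Compound 1 `COc1ccc(Cc2nnc(NC(=O)/C(C#N)=C/c3ccccc3OS(=O)(=O)c3ccc(OC)cc3)s2)cc1` gives 100%
Compound 2 `COc1ccc(Cc2nnc(NC(=O)/C(C#N)=C/c3ccccc3OS(=O)(=O)c3ccc(Cl)cc3)s2)cc1` gives 20%
Compound 3 `COc1ccc(S(=O)(=O)Oc2ccccc2/C=C(\C#N)C(=O)Nc2nnc(Cc3ccc(F)cc3)s2)cc1` is not yet measured

In a functional assay on HL-60 cells (Homo sapiens) for inhibition, read by CCK-8 assay, with a stated time of 48 h, tested at 20 uM (on this read-out lower numbers stand for less inhibition of growth and higher numbers for more inhibition of growth at the one concentration tested), compound 1 stands highest of the two measured numbers. Compound 3 differs from it by fluoro in place of methoxy on an aromatic carbon and the change reads 4-methoxybenzyl to 4-fluorobenzyl. Going by the values given here, the only measured step is a number 80 percentage points lower from compound 1 to compound 2 (beyond the scatter) and it replaces the other methoxy of compound 1 with chloro, so it bears on this change only loosely. A drop in this assay is expected, smaller than that large step. An estimated a number 40 percentage points lower from compound 1 to compound 3 (beyond the scatter) is expected on this basis. The estimate for compound 3 is 60% with an expected range from 20% to 100% in this series.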

Compound 3, percent growth inhibition at one concentration: 100%
Compound 3: the middle estimate sits 40 percentage points below what was measured; the range from low to high includes it.
By their numbers in this assay, from the lowest: compound 2; then compounds 1 and 3 (each within the scatter of the next).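

In this assay the change from 4-methoxybenzyl to 4-fluorobenzyl shows no change at the digits printed from compound 1 to compound 3 (within the scatter) and so this methoxy can give way to fluoro without a readable loss. The other methoxy of compound 1 behaves differently, with chloro in its place giving a number 80 percentage points lower from compound 1 to compound 2 (beyond the scatter) as the step. Nothing measured on these compounds accounts for this contrast between the two methoxy groups.

Open, as far as these compounds go, is whether an amine or a carboxylic acid in place of the fluoro would keep the growth inhibition. The single test concentration also leaves open whether compound 1 and compound 3 would separate at lower concentrations.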